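Swapping an ethynyl for a cyano on a cytotoxicity-tested macrocycle

The compounds below may be only part of what the source reports. "The series", "measured", "known", "first", "only" and "open" are said of these compounds alone.

Compound 1 `C#C[C@@H]1CCCN1S(=O)(=O)NC(=O)[C@@]12C[C@H]1/C=C\CCCCN(C)C(=O)N[C@@H](CCOc1cc(-c3nc(C(C)C)cs3)nc3c(Cl)c(OC)ccc13)C(=O)N2`: 21200 nM
Compound 2 `COc1ccc2c(OCC[C@@H]3NC(=O)N(C)CCCCC/C=C\[C@@H]4C[C@@]4(C(=O)NS(=O)(=O)C4CC4)NC3=O)cc(-c3ccccc3)nc2c1`: 53000 nM

In an ADME assay on cells (Homo sapiens) for activation (a higher number here means that more compound is tolerated, a lower number that less compound is tolerated), compound 1 gives 21200 nM, the lower of the two numbers measured; compound 2 gives a higher value, a gap beyond the scatter. Compound 3 `COc1ccc2c(OCC[C@@H]3NC(=O)N(C)CCCC/C=C\[C@@H]4C[C@@]4(C(=O)NS(=O)(=O)N4CCC[C@H]4C#N)NC3=O)cc(-c3nc(C(C)C)cs3)nc2c1Cl` differs from compound 1 in one place: cyano in place of ethynyl on a saturated ring carbon. For the measured compounds named here, no measured pair shows this exact change, so the step of a 1.1-fold higher number from compound 1 to compound 3 (0.05 log units; within the scatter) is expected to stay within the scatter, in no clear direction. Compound 3 is therefore estimated at 24000 nM, with a range from 10000 nM to 60000 nM.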

Compound 3, half-maximal cytotoxic concentration: 28300 nM
Compound 3: middle estimate off by 1.2-fold (0.07 log units), on the low side, and the stated range covers the measured number.
By their numbers in this assay, from the lowest: compounds 1, 3 and 2 (each within the scatter of the next, the first and the last beyond it).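

On the saturated ring carbon next to the ring nitrogen, replacing ethynyl with cyano gives a 1.3-fold higher number from compound 1 to compound 3 (0.13 log units; within the scatter) in this assay. For the compounds shown here, this is the first direct reading of this change: adding one hydrogen-bond acceptor at this position leaves the tolerated concentration within the usual scatter. No supporting data bear on this result.

Still open, from the compounds shown here alone, is whether a carboxylic acid or an amine on this same carbon would also stay within the scatter. Going by these compounds, whether the cyano-for-ethynyl swap behaves the same way on a different core also remains unknown.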